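Replacing a Methylsulfonyl Ring with a Dichloro Hydroxymethyl Ring

The source may hold more compounds than are shown below. What is called first, only, known or untested is meant among the compounds shown, and "the series" means these compounds.

Compound 1 `Cc1cccc(C)c1Nc1nc2c(Nc3ccc(C(F)(F)F)cc3)ncnc2s1`: 23 nM
Compound 2 `CSc1ccccc1Nc1nc2c(Nc3ccc(C(F)(F)F)cc3)ncnc2s1`: 43 nM
Compound 3 `CS(=O)(=O)c1ccccc1Nc1nc2c(Nc3ccc(C(F)(F)F)cc3)ncnc2s1`: 234 nM

In a functional assay on HEK293 cells for antagonist activity at transient receptor potential cation channel subfamily V member 1 (Homo sapiens), read by calcium flux (on this read-out lower numbers stand for stronger inhibition and higher numbers for weaker inhibition), compound 3 gives the highest number of the three: the steps of a 10-fold higher number from compound 1 to compound 3 (1.01 log units; beyond the scatter) and a 5.4-fold higher number from compound 2 to compound 3 (0.74 log units; beyond the scatter) both lead to it, and both lie beyond the scatter. Compound 4 `OCc1cc(Cl)c(Nc2nc3c(Nc4ccc(C(F)(F)F)cc4)ncnc3s2)c(Cl)c1` is the next compound, and it changes compound 3 in one place: 2,6-dichloro-4-(hydroxymethyl)phenyl in place of 2-(methylsulfonyl)phenyl on a nitrogen on an aromatic ring. The 2,6-dichloro-4-(hydroxymethyl)phenyl ring of compound 4 resembles the 2,6-dimethylphenyl ring of compound 1 more than the 2-(methylsulfonyl)phenyl ring of compound 3, so the large step seen from compound 1 to compound 3 is expected to be largely undone, giving a lower number. Compound 4 is therefore estimated at 35 nM, between 10 nM and 120 nM, a change of a 6.7-fold lower number from compound 3 to compound 4 (0.83 log units; beyond the scatter).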

Compound 4, half-maximal inhibitory concentration: 1 nM
Beside the measured number, compound 4's estimate is 35-fold (1.54 log units) above it, outside the stated range (below it).
By their numbers in this assay, from the lowest: compound 4; then compounds 1 and 2 (each within the scatter of the next); then compound 3.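

In this assay, the 2,6-dichloro-4-(hydroxymethyl)phenyl ring shows that this position can carry far stronger inhibition than the earlier rings suggested (a 230-fold lower number from compound 3 to compound 4 (2.37 log units; beyond the scatter)). The new ring does more than recover the level of the 2,6-dimethylphenyl ring (a 23-fold lower number from compound 1 to compound 4 (1.36 log units; beyond the scatter)), and it also surpasses the 2-(methylsulfanyl)phenyl ring (a 43-fold lower number from compound 2 to compound 4 (1.63 log units; beyond the scatter)). No evidence here explains this gain.

The compounds shown do not separate the contribution of the chlorine atoms from that of the hydroxymethyl group. From the compounds shown here alone, whether a plain 2,6-dichlorophenyl ring, or a carboxylic acid or amine in place of the hydroxymethyl, would perform as well remains open.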